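A few compounds are considered here, and "the series" means these few. Any claim that something is new, unique, unknown or untested is made for them only; others in the source may bear on it.

The study tested two compounds in a functional assay on MCF7 cells (Homo sapiens) for cytotoxicity, read by MTT assay, with a stated time of 72 h; on this read-out higher numbers stand for lower toxicity in this test and lower numbers for higher toxicity in this test. Compound 1, `COc1ccc(OC(=O)Nc2ccc([Se]C#N)cc2)cc1`, gives 74100 nM in this assay. Compound 2, `Cc1ccc(OC(=O)Nc2ccc([Se][Se]c3ccc(NC(=O)Oc4ccc(C)cc4)cc3)cc2)cc1`, gives 74000 nM in this assay, so the two numbers lie within the scatter of each other and compound 1 cannot be set apart from compound 2 on the numbers shown. Compound 3, `N#C[Se]c1ccc(NC(=O)Oc2ccccc2)cc1`, differs from compound 1 by hydrogen in place of methoxy on an aromatic carbon. Among the compounds with values here, no measured pair carries a comparable change, so the step of a 1.1-fold lower number from compound 1 to compound 3 (0.02 log units; within the scatter) is expected to be small, with no direction beyond the scatter. Compound 3 is estimated at 70000 nM, within 35000 nM to 140000 nM.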

Compound 3, concentration lethal to 50% of the cells: 67800 nM
For compound 3 the middle estimate is 1.0-fold (0.01 log units) above the measured one, and the stated range covers the measured number.
By their numbers in this assay, from the lowest: compounds 3, 2 and 1 (each within the scatter of the next).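

With hydrogen in place of methoxy on an aromatic carbon, para to a large group, the result is a 1.1-fold lower number from compound 1 to compound 3 (0.04 log units; within the scatter) in this assay. Within the data shown here, this is the first single-place comparison, and it shows that on the core of compound 1 this exchange at this position leaves the number within the scatter. No available evidence bears on why this is so.

Going by these compounds, whether an amine, a carboxylic acid or a longer chain such as butoxy at this position would move the number beyond the scatter remains open.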